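A few compounds are considered here, and "the series" means these few. Any claim that something is new, unique, unknown or untested is made for them only; others in the source may bear on it.

In an ADME assay on L6 cells (Rattus norvegicus) for cytotoxicity, read by resazurin assay, with a stated time of 72 h (a higher number here means a weaker inhibitor, a lower number a stronger inhibitor), three compounds sharing one core have been measured. Compound 1 `CC(C)Oc1ccc(C(O)(c2ccc(C(F)(F)F)cc2)c2cccnc2)cc1` gives 47600 nM. Compound 2 `N#Cc1ccc(C(O)(c2ccc(C(F)(F)F)cc2)c2cccnc2)cc1` gives 76500 nM. Compound 3 `OC(c1ccc(C(F)(F)F)cc1)(c1ccc(C(F)(F)F)cc1)c1cccnc1` gives 50600 nM. Compound 2 thus sits within the usual scatter of both other compounds, so these numbers separate none of the three.

Compound 4 `OC(c1ccc(C(F)(F)F)cc1)(c1cccnc1)c1cc2ccccc2s1` has not been measured yet. Its difference from compound 2 is this: 1-benzothiophen-2-yl in place of 4-cyanophenyl on a saturated chain carbon bound to two aromatic carbons and an oxygen on a saturated carbon.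

The nearest evidence comes from three swaps of one group on an aromatic carbon: a 1.6-fold higher number from compound 1 to compound 2 (0.21 log units; within the scatter), a 1.1-fold higher number from compound 1 to compound 3 (0.03 log units; within the scatter) and a 1.5-fold lower number from compound 2 to compound 3 (0.18 log units; within the scatter). All three lie within the scatter. Among the compounds with values here, none of them replaces the whole 4-cyanophenyl group, however, and no measured compound carries 1-benzothiophen-2-yl, so they bear on this change only indirectly. They give no reason to expect a real shift in either direction, although the uncertainty is wider than for those swaps.

The estimated change is a 1.5-fold lower number from compound 2 to compound 4 (0.18 log units; within the scatter), which is no step beyond the scatter. For compound 4, the expected value is 50000 nM, with an estimated range from 20000 nM to 100000 nM.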

Compound 4, half-maximal inhibitory concentration: 58700 nM
For compound 4 the middle estimate is 1.2-fold (0.07 log units) below the measured one; low and high end bracket the measured number.
By their numbers in this assay, from the lowest: compounds 1, 3, 4 and 2 (each within the scatter of the next).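

In this assay, within the data shown here, the earlier steps changed only a single group on an aromatic carbon, while this one replaces an entire aromatic group on the saturated chain carbon. Putting 1-benzothiophen-2-yl in place of 4-cyanophenyl gives a 1.3-fold lower number from compound 2 to compound 4 (0.12 log units; within the scatter), so even this larger swap, which adds a five-membered aromatic ring and removes the triple bond, produces no readable change here. No other measurement bears on this result or offers an explanation for it.

The compounds shown leave open whether any group at this place can move the number beyond the scatter, since all four compounds carry an aromatic group there. An open-chain group such as a longer alkyl chain, or one bearing an amine, could test this.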